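A few compounds are considered here, and "the series" means these few. Any claim that something is new, unique, unknown or untested is made for them only; others in the source may bear on it.

Measured so far in a functional assay on the whole organism (strain Sprague-Dawley) for inhibition, with Rattus norvegicus as the target, with a stated time of 10 min (a higher number here means that more compound is needed for the effect, a lower number that less compound is needed), are these:
compound 1 `CCOC(=O)c1cnc(-c2ccccc2OC)[nH]c1=O` gives 10 mg/kg
compound 2 `CCCOc1ccccc1-c1ncc(C(=O)OCC)c(=O)[nH]1` gives 5 mg/kg
compound 3 `CCOC(=O)c1cnc(-c2ccccc2OCC(C)C)[nH]c1=O` gives 3 mg/kg

Compound 3, at 3 mg/kg in this assay, lies within the scatter of compound 2 and apart from compound 1, so it belongs to the low end of the three numbers. Compound 4 `CCCCCOc1ccccc1-c1ncc(C(=O)OCC)c(=O)[nH]1` has butyl in place of isopropyl on a saturated chain carbon bound to an oxygen on an aromatic ring, which also reads as isobutoxy to pentyloxy.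

Within the data shown here, three measured steps concern this same chain. The first is a 2.0-fold lower number from compound 1 to compound 2 (0.30 log units; within the scatter), the second is a 3.3-fold lower number from compound 1 to compound 3 (0.52 log units; beyond the scatter), and the third is a 1.7-fold lower number from compound 2 to compound 3 (0.22 log units; within the scatter). All three run towards lower numbers, but only the second clears the scatter. The third, the only one that starts from a chain longer than that of compound 1, does not. Among the measured compounds shown here, no measured compound carries a pentyloxy chain, so the new chain lies outside what has been tested, and no change beyond the scatter is expected. The expected step is no change at the digits printed from compound 3 to compound 4 (within the scatter) in this estimate. For compound 4 the expected value is 3 mg/kg, with an estimated range of 1.2 mg/kg to 8 mg/kg.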

Compound 4, dose for 50% inhibition: 2 mg/kg
Beside the measured number, compound 4's estimate is 1.5-fold (0.18 log units) above it, and the stated range covers the measured number.
By their numbers in this assay, from the lowest: compounds 4, 3, 2 and 1 (each within the scatter of the next, the first and the last beyond it).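

In this assay, isobutoxy to pentyloxy gives a 1.5-fold lower number from compound 3 to compound 4 (0.18 log units; within the scatter), so butyl in place of isopropyl on a saturated chain carbon bound to an oxygen on an aromatic ring brings no readable change, and neither compound 3 nor compound 4 can be ranked above the other. The new chain does separate from the shorter ones, with a 2.5-fold lower number from compound 2 to compound 4 (0.40 log units; beyond the scatter) and a 5.0-fold lower number from compound 1 to compound 4 (0.70 log units; beyond the scatter), whereas the earlier step from compound 2 to compound 3 stayed within the scatter, so this position now shows a second compound, after compound 3, that stands clear of compound 1 and the first that stands clear of compound 2. No supporting measurement bears on the reason for these differences.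

The compounds shown leave open whether a longer chain such as hexyloxy continues the run towards lower numbers or whether it levels off at this length, and whether an amine or a ring at the end of the chain would be accepted at this position. They also leave open how far the chain effect holds with a carboxylic acid in place of the ethyl ester on the shared core.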